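Methoxy to hydroxy on the aryl ring of compound 3

A few compounds are considered here, and "the series" means these few. Any claim that something is new, unique, unknown or untested is made for them only; others in the source may bear on it.

Among the three measured compounds, compound 3 `COc1cc(C)cc(-c2nn(CC#N)cc2-c2ccnc(-c3ccc(N(C)C)cc3)c2)c1` gives the lowest number in a functional assay on NCI-H23 cells (Homo sapiens) for inhibition, read by sulforhodamine B assay, with a stated time of 48 h (on this read-out higher numbers stand for weaker inhibition of growth and lower numbers for stronger inhibition of growth), at 514 nM. Compound 2 `Cc1cc(O)cc(-c2nn(CC#N)cc2-c2ccnc(-c3ccc(Oc4ccccc4)cc3)c2)c1` gives 1940 nM, and compound 1 `COc1cc(C)cc(-c2c(-c3ccnc(-c4ccc(C(C)=O)cc4)c3)cnn2CC#N)c1` gives 3900 nM; both gaps to compound 3 lie beyond the scatter. Compound 4 `Cc1cc(O)cc(-c2nn(CC#N)cc2-c2ccnc(-c3ccc(N(C)C)cc3)c2)c1` has not been measured in this assay. It differs from compound 3 by hydrogen in place of methyl on an oxygen on an aromatic ring. Among the measured compounds shown here, no pair of measured compounds shows this change alone, so there is nothing here that sets its direction. The step from compound 3 to compound 4 is therefore expected to be small, with the size a 1.2-fold higher number from compound 3 to compound 4 (0.07 log units; within the scatter), likely within the scatter. Compound 4 is accordingly estimated at 600 nM, with a range from 200 nM to 2000 nM.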

Compound 4, concentration for 50% growth inhibition: 4480 nM
Compound 4: middle estimate off by 7.5-fold (0.87 log units), on the low side; measured number above the stated range.
By their numbers in this assay, from the lowest: compound 3; then compounds 2, 1 and 4 (each within the scatter of the next, the first and the last beyond it).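

In this assay, hydroxy cannot stand in for methoxy on this aryl ring: the change gives an 8.7-fold higher number from compound 3 to compound 4 (0.94 log units; beyond the scatter) and costs compound 3 its low number. With the hydroxy in place, dimethylamino in place of phenoxy gives a 2.3-fold higher number from compound 2 to compound 4 (0.36 log units; beyond the scatter) and so does not restore that low number; the gain seen with dimethylamino in compound 3 does not carry over to the hydroxy compounds. Nothing given here accounts for either step. On these data alone, whether ethoxy or an amine at this place would keep the number of compound 3 remains open, as does how phenoxy behaves alongside methoxy.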